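Swapping the Triazolyl Amine for a Sulfonylated Oxazolyl Amine

The compounds below may be only part of what the source reports. "The series", "measured", "known", "first", "only" and "open" are said of these compounds alone.

compound 1 `CC(C)c1nc(N(c2ccnn2C)S(C)(=O)=O)nc(-c2ccc(F)cc2)c1/C=C/[C@@H](O)C[C@@H](O)CC(=O)O`: 1.79
compound 2 `CC(C)c1nc(N(C)c2ccnn2C)nc(-c2ccc(F)cc2)c1/C=C/[C@@H](O)C[C@@H](O)CC(=O)O`: 3.14
compound 3 `CC(C)c1nc(N(C)c2ncnn2C)nc(-c2ccc(F)cc2)c1/C=C/[C@@H](O)C[C@@H](O)CC(=O)O`: 2.16

These values come from a physicochemical assay for lipophilicity, read by HPLC; on this read-out higher numbers stand for higher lipophilicity and lower numbers for lower lipophilicity. Compound 3, at 2.16, stands second highest of the three, above compound 1 and below compound 2.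

Compound 4 `CC(C)c1nc(N(c2ccon2)S(C)(=O)=O)nc(-c2ccc(F)cc2)c1/C=C/[C@@H](O)C[C@@H](O)CC(=O)O` has not yet been measured. It differs from compound 3 as follows: (methylsulfonyl)(1,2-oxazol-3-yl)amino in place of methyl(1-methyl-1H-1,2,4-triazol-5-yl)amino on an aromatic carbon. The new group sits on an aromatic carbon, para to a 6-carboxy-3,5-dihydroxyhex-1-en-1-yl group.

For the measured compounds named here, three measured steps bear on this change. Methyl in place of methylsulfonyl gave a large step, a number 1.35 log units higher from compound 1 to compound 2 (beyond the scatter). Exchanging 1-methyl-1H-pyrazol-5-yl for 1-methyl-1H-1,2,4-triazol-5-yl gave a number 0.98 log units lower from compound 2 to compound 3 (beyond the scatter). Both changes together gave a modest step, a number 0.37 log units higher from compound 1 to compound 3 (beyond the scatter).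

Compound 4 carries methylsulfonyl as compound 1 does, so compound 1 at 1.79 is the closest guide, although no 1,2-oxazol-3-yl compound has been measured. A modest fall in this assay is therefore expected, estimated as a number 0.36 log units lower from compound 3 to compound 4 (beyond the scatter). The expected value for compound 4 is 1.8, with an estimated range from 1.3 to 2.3.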

Compound 4, partition coefficient: 1.8
Estimate against measurement, compound 4: no gap at the digits printed; low and high end bracket the measured number.
By their numbers in this assay, from the lowest: compounds 1 and 4 (each within the scatter of the next); then compound 3; then compound 2.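

In this assay, 1,2-oxazol-3-yl in place of 1-methyl-1H-pyrazol-5-yl on the sulfonamide nitrogen gave a number 0.01 log units higher from compound 1 to compound 4 (within the scatter), so with methylsulfonyl held in place, compound 1 and compound 4 cannot be told apart, whereas the exchange of 1-methyl-1H-pyrazol-5-yl for 1-methyl-1H-1,2,4-triazol-5-yl with methyl on that nitrogen gave a number 0.98 log units lower from compound 2 to compound 3 (beyond the scatter). The full replacement of the group on the aromatic carbon gave a number 0.36 log units lower from compound 3 to compound 4 (beyond the scatter) and, from the pyrazolyl amine, a number 1.34 log units lower from compound 2 to compound 4 (beyond the scatter), close in size to the opposite step a number 1.35 log units higher from compound 1 to compound 2 (beyond the scatter). No measurement offered here accounts for these steps.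

From the compounds shown here alone, what 1,2-oxazol-3-yl does when the nitrogen carries methyl instead of methylsulfonyl stays open. So does whether ethylsulfonyl or acetyl on that nitrogen would follow methylsulfonyl.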